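Chloro substitution on the benzamide ring of compound 1

The compounds below may be only part of what the source reports. "The series", "measured", "known", "first", "only" and "open" are said of these compounds alone.

For the measured compounds named here, compound 1 `O=C(Nc1nnc(-c2cccc(O)c2O)s1)c1ccccc1` sits at the low end of the three numbers so far: in an ADME assay on MRC5 cells (Homo sapiens) for cytotoxicity, read by MTT assay, with a stated time of 72 h (on this read-out higher numbers stand for weaker inhibition and lower numbers for stronger inhibition), compound 1 gives 23200 nM, with compound 3 `O=C(Nc1nnc(-c2ccc(O)c(O)c2)s1)C1CCCCC1` at 24000 nM and compound 2 `O=C(Nc1nnc(-c2ccc(O)c(O)c2)s1)c1ccc(Cl)cc1` at 30600 nM, all within the scatter of one another, so no order among them is claimed. Going by the values given here, the only one-place step measured, a 1.3-fold lower number from compound 2 to compound 3 (0.11 log units; within the scatter), stays within the scatter as well.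

Compound 4 `O=C(Nc1nnc(-c2cccc(O)c2O)s1)c1ccc(Cl)cc1` differs from compound 1 by chloro in place of hydrogen on an aromatic carbon, which cut one bond further out reads phenyl to 4-chlorophenyl. Among the compounds with values here, no measured pair isolates exactly this change; compound 2 carries the 4-chlorophenyl and compound 1 the phenyl, but their hydroxyl pattern differs too, and their values lie within the scatter of each other. Across all three compounds the carbonyl substituent has moved the number by less than the scatter. Compound 4 is therefore expected to show a 1.1-fold higher number from compound 1 to compound 4 (0.05 log units; within the scatter), no step beyond the scatter. The estimate for compound 4 is 26000 nM, from 12000 nM to 55000 nM.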

Compound 4, half-maximal inhibitory concentration: 18700 nM
The estimate for compound 4 lay 1.4-fold (0.14 log units) above the measured number; the range from low to high includes it.
By their numbers in this assay, from the lowest: compounds 4, 1, 3 and 2 (each within the scatter of the next).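

With the hydroxyl pattern of compound 1 held fixed, chloro in place of hydrogen on this aromatic carbon, para to a large group, can now be read on its own: in this assay it gives a 1.2-fold lower number from compound 1 to compound 4 (0.09 log units; within the scatter). Phenyl and 4-chlorophenyl are therefore not told apart by this read-out on this core, which the values of compound 1 and compound 2 could not show, as those two also differ in their hydroxyl pattern. No evidence on hand bears on this result.

From the compounds shown here alone, whether an amine, a carboxylic acid or a methoxy group at this position would give a step beyond the scatter remains open. Also open, going by these compounds, is whether chloro gives a step of similar size on the hydroxyl pattern of compound 2.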